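From 2,3-dichlorophenyl to 4-methoxyphenyl on a shared core

The compounds below may be only part of what the source reports. "The series", "measured", "known", "first", "only" and "open" are said of these compounds alone.

In a functional assay on A549 cells (Homo sapiens) for cytotoxicity, read by MTT assay, with a stated time of 72 h (a higher number here means a weaker inhibitor, a lower number a stronger inhibitor), compound 1 `COc1cc2ncnc(Nc3ccc(F)c(Cl)c3)c2cc1NC(=O)N/N=C/c1ccc(F)cc1` gives 26600 nM and compound 2 `COc1cc2ncnc(Nc3ccc(F)c(Cl)c3)c2cc1NC(=O)N/N=C/c1cccc(Cl)c1Cl` gives 35300 nM so the two stand level within the scatter. Compound 3 `COc1ccc(/C=N/NC(=O)Nc2cc3c(Nc4ccc(F)c(Cl)c4)ncnc3cc2OC)cc1` differs from compound 2 by one change 4-methoxyphenyl in place of 2,3-dichlorophenyl on a carbon with a double bond to nitrogen with 4-methoxyphenyl in place of 2,3-dichlorophenyl on a carbon with a double bond to nitrogen. Among the measured compounds shown here, the only measured swap at that place is a 1.3-fold higher number from compound 1 to compound 2 (0.12 log units; within the scatter) and it is a small one. No step beyond the scatter is therefore expected in this assay and the expected move is a 1.2-fold lower number from compound 2 to compound 3 (0.07 log units; within the scatter) on this single precedent. The estimate for compound 3 is 30000 nM with a range of 12000 nM to 70000 nM as its expected span.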

Compound 3, half-maximal inhibitory concentration: 28100 nM
For compound 3 the middle estimate is 1.1-fold (0.03 log units) above the measured one, and the stated range covers the measured number.
By their numbers in this assay, from the lowest: compounds 1, 3 and 2 (each within the scatter of the next).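

Putting 4-methoxyphenyl in place of 2,3-dichlorophenyl on the carbon with a double bond to nitrogen leaves the two compounds level in this assay (a 1.3-fold lower number from compound 2 to compound 3 (0.10 log units; within the scatter)). Methoxy in place of fluoro on an aromatic carbon also stays within the scatter (a 1.1-fold higher number from compound 1 to compound 3 (0.02 log units; within the scatter)), so all three substituted phenyl groups at this place now stand level, whether they carry halogen or an oxygen-bearing group. Nothing given here bears on why they stand level. From the compounds shown here alone, whether an amine or a carboxylic acid on that phenyl ring, or a longer chain in place of the ring, would give a step beyond the scatter remains open.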